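The source may report more compounds than this note shows. Statements on the series, on what has been measured and on what is new or still open speak of the compounds shown alone.

Measured so far in an assay on CHO cells for displacement of a labelled ligand from adenosine receptor A1 (Homo sapiens), read by scintillation counting, with a stated time of 90 min, tested at 1 uM, in the presence of a further agent that is not named here; on this read-out lower numbers stand for less inhibition and higher numbers for more inhibition at the one concentration tested (going by the name of the read-out):
compound 1 `CCCn1c(=O)[nH]c2nc(-c3ccc(S(=O)(=O)N4CCN(c5cccc(Br)c5)CC4)cc3)[nH]c2c1=O` gives -1%
compound 2 `CCCn1c(=O)c2[nH]c(-c3ccc(S(=O)(=O)N4CCN(c5ccc(Cl)cc5)CC4)cc3)nc2n(CC)c1=O` gives 24%
compound 3 `CCCn1c(=O)[nH]c2nc(-c3ccc(S(=O)(=O)N4CCN(c5ccccc5)C(C)C4)cc3)[nH]c2c1=O` gives 15%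

Compound 1 stands lowest of the three numbers. Compound 3 gives 15%, a number higher than that of compound 1 by more than the usual scatter of this kind of measurement, and compound 2 gives 24%, the highest of the three, also beyond the scatter from compound 1. Going by the values given here, none of these three compounds differs from another in only one place, so no single step between measured compounds is known.

Compound 4 `CCCn1c(=O)[nH]c2nc(-c3ccc(S(=O)(=O)N4CCN(Cc5ccc(Br)cc5)CC4)cc3)[nH]c2c1=O` has not yet been measured. It differs from compound 1 in one place: 4-bromobenzyl in place of 3-bromophenyl on an amine nitrogen in a ring. Among the compounds with values here, no measured pair shows a change of this kind, so the data give no direct guide to its size or direction. Since all three measured numbers are modest, a small step is expected for compound 4, of size a number 6 percentage points higher from compound 1 to compound 4 (within the scatter), not beyond the scatter. Compound 4 is therefore estimated at 5%, with a range from -12% to 25%.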

Compound 4, a percentage reported as inhibition, at one concentration (the size of the read-out at that concentration, not a potency): 31%
Estimate against measurement, compound 4: 26 percentage points below; the measured number lies above the stated range.
By their numbers in this assay, from the lowest: compound 1; then compounds 3, 2 and 4 (each within the scatter of the next, the first and the last beyond it).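

In this assay, the group on this amine nitrogen in a ring clearly matters: placing 4-bromobenzyl there in place of 3-bromophenyl gives a number 32 percentage points higher from compound 1 to compound 4 (beyond the scatter). Going by these compounds alone, this is the first readable step in the set, but the swap changes two things at once: 4-bromobenzyl holds 7 carbon where 3-bromophenyl holds 6, and the number in each name shows that the bromine's place differs, so neither change can be credited alone. Nothing measured here explains the rise.

Still open, on these data alone, is which change carries the step, something that 3-bromobenzyl would help to separate, along with whether the bromine is needed at all, as plain benzyl would show. A longer chain such as 2-phenylethyl would test whether the trend continues.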